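Sulfamide to sulfamate: a chain swap on the sulfonyl sulfur

The source may hold more compounds than are shown below. What is called first, only, known or untested is meant among the compounds shown, and "the series" means these compounds.

Of the compounds shown here, two have been measured in an assay on liver for inhibition of sterol O-acyltransferase 1 (Rattus norvegicus), using microsomes; on this read-out higher numbers stand for weaker inhibition and lower numbers for stronger inhibition. Compound 1 `CC(C)NS(=O)(=O)NC(=O)Nc1c(C(C)C)cccc1C(C)C` gives 18000 nM in this assay. Within the data shown here, compound 2 `CCCCN(CC)S(=O)(=O)NC(=O)Nc1c(C(C)C)cccc1C(C)C` gives 1200 nM in this assay, the lowest of the two numbers, and the single measured step, a 15-fold lower number from compound 1 to compound 2 (1.18 log units; beyond the scatter), separates it from compound 1. Compound 3 `CCCCCCOS(=O)(=O)NC(=O)Nc1c(C(C)C)cccc1C(C)C` is not yet measured; it differs from compound 2 by hexyloxy in place of butyl(ethyl)amino on a sulfonyl sulfur. The measured step concerns a different exchange on the same sulfonyl sulfur, between two amino groups, whereas the change to compound 3 replaces an amino group by an alkoxy group while keeping the count of heavy atoms unchanged. Among the measured compounds shown here, no measured pair tests an amino-to-alkoxy exchange, so its effect is unknown. Compound 3 is therefore expected to land near compound 2, with an estimated step of a 1.7-fold higher number from compound 2 to compound 3 (0.22 log units; within the scatter). Compound 3 is estimated at 2000 nM in this assay, within a range of 500 nM to 8000 nM.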

Compound 3, half-maximal inhibitory concentration: 27000 nM
For compound 3 the middle estimate is 14-fold (1.13 log units) below the measured one, and the stated range ends below it.
By their numbers in this assay, from the lowest: compound 2; then compounds 1 and 3 (each within the scatter of the next).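

In this assay the sulfonyl sulfur responds to more than the size of its substituent: with the heavy-atom count unchanged, hexyloxy in place of butyl(ethyl)amino gives a 23-fold higher number from compound 2 to compound 3 (1.35 log units; beyond the scatter) and so costs compound 3 much of the inhibition seen in compound 2. Set against the isopropylamino group, the same hexyloxy group gives a 1.5-fold higher number from compound 1 to compound 3 (0.18 log units; within the scatter) and stays within the scatter, so a long chain on this sulfur does not by itself bring the stronger inhibition of compound 2. Nothing available here explains the weakening seen with hexyloxy.

From the compounds shown here alone, what a hexylamino group on the same sulfur would give, and thus whether the weakening follows the oxygen link or the loss of the second chain on nitrogen, remains open. Going by these compounds, the effect of a shorter alkoxy group such as butoxy also remains open.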